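The compounds below may be only part of what the source reports. "The series", "measured", "known", "first", "only" and "open" are said of these compounds alone.

Among the compounds with values here, compound 2 `Oc1ccc(-c2cc(-c3cccc(Cl)c3)nc(-c3cccs3)c2)cc1` gives the lowest of the two numbers measured so far in a functional assay on HCT-15 cells (Homo sapiens) for cytotoxicity, read by CCK-8 assay and cell counting, with a stated time of 2 days (a higher number here means a weaker inhibitor, a lower number a stronger inhibitor), namely 5050 nM. Its nearest neighbour, compound 1 `Oc1ccc(-c2cc(-c3cccc(Cl)c3)nc(-c3ccccn3)c2)cc1`, gives 28200 nM in this assay. Within the data shown here, the one measured step, a 5.6-fold lower number from compound 1 to compound 2 (0.75 log units; beyond the scatter), swaps one small aromatic ring for another. Compound 3 `Oc1ccc(-c2cc(-c3cccnc3)nc(-c3cccc(Cl)c3)c2)cc1` differs from compound 2 by pyridin-3-yl in place of thiophen-2-yl on an aromatic carbon. Among the measured compounds shown here, that single step is the only guide, and it ran toward the five-membered ring. For compound 3 the expected step in this assay is therefore a modest rise of a 2.4-fold higher number from compound 2 to compound 3 (0.38 log units; beyond the scatter). For compound 3 the estimated value is 12000 nM, within a range from 4000 nM to 35000 nM.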

Compound 3, half-maximal inhibitory concentration: 21300 nM
The estimate for compound 3 lay 1.8-fold (0.25 log units) below the measured number, and the stated range covers the measured number.
By their numbers in this assay, from the lowest: compound 2; then compounds 3 and 1 (each within the scatter of the next).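

In this assay, the pyridin-3-yl ring does not keep the lower number seen with thiophen-2-yl, with a 4.2-fold higher number from compound 2 to compound 3 (0.63 log units; beyond the scatter) as the result. Changing which pyridine sits at this position makes no clear difference, with a 1.3-fold lower number from compound 1 to compound 3 (0.12 log units; within the scatter) lying within the scatter, so here both pyridines stand apart from thiophen-2-yl. No evidence is available to explain this gap. The compounds shown leave open whether a furan-2-yl or plain phenyl ring at this position would give a number like that of thiophen-2-yl or those of the pyridines.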